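The source may report more compounds than this note shows. Statements on the series, on what has been measured and on what is new or still open speak of the compounds shown alone.

Compound 1 `COc1cc(-c2nnc(SCc3ccccc3)n2/N=C/c2ccccc2)cc(OC)c1OC` — in a functional assay on HepG2 cells (Homo sapiens) for cytotoxicity, read by MTT assay, with a stated time of 48 h (on this read-out lower numbers stand for stronger inhibition and higher numbers for weaker inhibition), compound 1 gives > 200000 nM, which is a limit of the assay and not a number.
Compound 2 `COc1cc(-c2nnc(SCc3ccc(F)cc3)n2/N=C/c2ccccc2)cc(OC)c1OC` — in this assay compound 2 gives > 200000 nM, again a limit rather than a number.
Compound 3 `COc1ccc(/C=N/n2c(SCc3ccc(F)cc3)nnc2-c2cc(OC)c(OC)c(OC)c2)c(OC)c1` — in this assay compound 3 gives > 200000 nM, also a limit.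

Compound 3 therefore stands where the whole series stands: at the limit of > 200000 nM in this assay, at which 3 of the 3 values shown sit. For the measured compounds named here, no compound in this set has a readable number. The step that the two limits leave unreadable from compound 1 to compound 2 and the step that the two limits leave unreadable from compound 2 to compound 3 are both unreadable because the limit of > 200000 nM in this assay, at which 3 of the 3 values shown sit, caps every value, so neither offers a size or a direction that could be carried forward.

Compound 4 `CCOC(=O)CSc1nnc(-c2cc(OC)c(OC)c(OC)c2)n1/N=C/c1ccc(OC)cc1OC` is the next compound. It differs from compound 3 in one place: ethoxycarbonyl in place of 4-fluorophenyl on a saturated chain carbon bound to a sulfur. Going by the values given here, no measured step touches the saturated chain carbon bound to the sulfur, so there is no direct precedent for this change, and the two steps that do exist are unreadable.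

The expectation for compound 4 rests only on the observation that compound 1, compound 2 and compound 3 all sit at the limit. Compound 4 is expected to remain in the same region, with an estimated value of 200000 nM, in the range 60000 nM to 600000 nM. The expected step of a number no higher from compound 3 to compound 4 (the limit leaves the size open) is estimated as essentially none beyond the scatter, and a further limit rather than a number is the most likely outcome.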

Compound 4, half-maximal inhibitory concentration: > 200000 nM
Compound 4 was reported as a limit; the forecaster's own chance of this, stated with the estimate: 80%; the middle value lies on the limit itself.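

In this assay compound 4 gives > 200000 nM, which is a limit and not a number. The change from compound 3 to compound 4 therefore yields no readable step, as every value is capped: the limit of > 200000 nM in this assay, at which 4 of the 4 values shown sit.

Compound 1, compound 2, compound 3 and compound 4 leave open whether any change among them alters the read-out in this assay.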